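This account rests on a few compounds, and the source may have more. Where it says the series, first, only, none or still open, it means among the compounds named here.

Measured compounds:
compound 1 `CCCCCOc1cccc(C(=O)Nc2cccc(C(=O)O)c2)c1` — 2540 nM
compound 2 `O=C(O)c1cccc(NC(=O)c2cccc(-c3cccc(OCC4CC4)c3)c2)c1` — 206 nM

In an assay on isolated protein for agonist activity at Bile acid receptor (Homo sapiens), read by TR-FRET, with a stated time of 3 h, in the absence of a further agent (a higher number here means that more compound is needed for the effect, a lower number that less compound is needed), compound 1 gives 2540 nM and compound 2 gives 206 nM. Compound 2 stands at the lowest number of the two; the nearest is compound 1, whose number is higher by a gap that lies beyond the scatter. Among the measured compounds shown here, the two differ in more than one place, so no single step is recorded between them, and what they show is only that the biaryl acid with a cyclopropylmethoxy group reaches a lower number than the pentyloxy anilide.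

Compound 3 `O=C(O)c1cccc(NC(=O)c2cccc(-c3cccc(OCCc4ccccc4)c3)c2)c1` is the next member, not yet measured in this assay. It arises from compound 2 by benzyl in place of cyclopropyl on a saturated chain carbon bound to an oxygen on an aromatic ring; cut one bond further out, this reads cyclopropylmethoxy to phenethyloxy. For the measured compounds named here, no measured pair shows this change, so the size of the step rests on no precedent. The expectation is a step of a 1.1-fold lower number from compound 2 to compound 3 (0.06 log units; within the scatter), within the scatter or only modestly outside it, with no clear direction. For compound 3 in this assay the estimate is 180 nM, with a range from 60 nM to 550 nM.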

Compound 3, half-maximal effective concentration: 169 nM
Estimate against measurement, compound 3: 1.1-fold (0.03 log units) above, and the stated range covers the measured number.
By their numbers in this assay, from the lowest: compounds 3 and 2 (each within the scatter of the next); then compound 1.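

In this assay, benzyl in place of cyclopropyl on a saturated chain carbon bound to an oxygen on an aromatic ring gives a 1.2-fold lower number from compound 2 to compound 3 (0.09 log units; within the scatter), so this read-out does not separate cyclopropylmethoxy from phenethyloxy. At this position, the entering group of 7 heavy atoms with a six-membered aromatic ring and the leaving group of 3 heavy atoms with a three-membered ring stand within the scatter of each other, a single-place comparison that compound 1 and compound 2, which differ in more than one place, could not give. No supporting data bear on why the number holds across this change.

Still open, on these data alone, is whether the same holds for an amine, a hydroxyl group or a longer chain such as 3-phenylpropyl in place of benzyl on that same carbon. Also open, as far as these compounds go, is whether the carboxylic acid of the shared core can be exchanged for a tetrazole or a methyl ester while the phenethyloxy group of compound 3 stays in place.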